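Trifluoromethyl in place of fluoromethyl: a lower number expected

The source may report more compounds than this note shows. Statements on the series, on what has been measured and on what is new or still open speak of the compounds shown alone.

Measured so far in a functional assay on isolated protein for inhibition of Glucose-dependent insulinotropic receptor (Rattus norvegicus), read by HTRF and cAMP accumulation; a lower number here means that less compound is needed, a higher number that more compound is needed for the effect:
Compound 1 `Cc1nc(S(C)(=O)=O)ccc1Oc1ncnc(OC2CCN(C(=O)OC(C)(C)C(F)(F)F)CC2)c1F` gives 47.2 nM.
Compound 2 `Cc1nc(S(C)(=O)=O)ccc1Oc1ncnc(OC2CCN(C(=O)OC(C)(C)C#N)CC2)c1F` gives 1320 nM.
Compound 3 `Cc1nc(S(C)(=O)=O)ccc1Oc1ncnc(OC2CCN(C(=O)O[C@H](C)CF)CC2)c1F` gives 1520 nM.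

Compound 3 has the highest number of the three. Its gap to compound 2 is small, a 1.2-fold higher number from compound 2 to compound 3 (0.06 log units; within the scatter), so the two cannot be told apart. Its gap to compound 1 is large, a 32-fold higher number from compound 1 to compound 3 (1.51 log units; beyond the scatter).

Compound 4 `Cc1nc(S(C)(=O)=O)ccc1Oc1ncnc(OC2CCN(C(=O)O[C@H](C)C(F)(F)F)CC2)c1F` differs from compound 3 in one place: trifluoromethyl in place of fluoromethyl on a saturated chain carbon bound to an oxygen next to a carbonyl group and a saturated chain carbon. For the measured compounds named here, two measured steps bear on this. Going from compound 1 to compound 3 removed a trifluoromethyl group together with a methyl and brought in a fluoromethyl, and the number rose sharply, a 32-fold higher number from compound 1 to compound 3 (1.51 log units; beyond the scatter). Going from compound 1 to compound 2 replaced the trifluoromethyl with cyano, and the number also rose sharply, a 28-fold higher number from compound 1 to compound 2 (1.45 log units; beyond the scatter). Both times the trifluoromethyl left and the number went up. Compound 4 brings the trifluoromethyl back, though without the extra methyl of compound 1, so only part of that large step is expected to be recovered. For compound 4 the expected step is a 13-fold lower number from compound 3 to compound 4 (1.10 log units; beyond the scatter), towards a lower number. Compound 4 is therefore estimated at 120 nM in this assay, between 40 nM and 400 nM.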

Compound 4, half-maximal effective concentration: 110 nM
Estimate against measurement, compound 4: 1.1-fold (0.04 log units) above; the measured number falls inside the stated range.
By their numbers in this assay, from the lowest: compound 1; then compound 4; then compounds 2 and 3 (each within the scatter of the next).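

In this assay, the step from fluoromethyl to trifluoromethyl is now seen on its own, with nothing else changing, and it is large (a 14-fold lower number from compound 3 to compound 4 (1.14 log units; beyond the scatter)). Compound 4 also has a much lower number than the nitrile-bearing compound 2 (a 12-fold lower number from compound 2 to compound 4 (1.08 log units; beyond the scatter)), so among these compounds the trifluoromethyl group on this carbon goes with the lower numbers, whether the carbon also carries the extra methyl or not. That extra methyl counts for much less: with the trifluoromethyl kept in place, taking it away gives only a modest rise, though one beyond the scatter (a 2.3-fold higher number from compound 1 to compound 4 (0.37 log units; beyond the scatter)), so most of the large gap between compound 1 and compound 3 follows the trifluoromethyl rather than the methyl.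

On these data alone, only fluoromethyl and trifluoromethyl are compared at this carbon, so it remains open whether difluoromethyl or a plain methyl would fall between them or outside them, and whether a longer chain such as pentafluoroethyl would lower the number further. Nothing measured here says why the trifluoromethyl group goes with the lower number.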